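This account rests on a few compounds, and the source may have more. Where it says the series, first, only, none or still open, it means among the compounds named here.

Compound 1 `Cc1ccc2nc(NC(=O)c3cn(-c4ccccc4)nc3-c3ccc(F)cc3)sc2c1`: in an ADME assay on HEK-293T cells (Homo sapiens) for cytotoxicity, read by MTT assay, with a stated time of 72 h (a higher number here means a weaker inhibitor, a lower number a stronger inhibitor), compound 1 gives > 50000 nM, which is a limit of the assay and not a number.
Compound 2 `Cc1ccc2nc(NC(=O)c3cn(-c4ccccc4)nc3-c3ccc(Cl)cc3)sc2c1`: compound 2 gives 35600 nM.
Compound 3 `COc1ccc(-c2nn(-c3ccccc3)cc2C(=O)Nc2nc3ccc(OC)cc3s2)cc1`: compound 3 gives > 50000 nM, again a limit of the assay rather than a number.

Compound 3 therefore stands at the upper edge of what this assay reports; it shares this position with compound 1, since two of the three values sit at the limit of > 50000 nM in this assay, at which 2 of the 3 values shown sit. Compound 4 `COc1ccc(-c2nn(-c3ccccc3)cc2C(=O)Nc2nc3ccc(C)cc3s2)cc1` differs from compound 3 by methyl in place of methoxy on an aromatic carbon. Among the measured compounds shown here, the only measured step, an at least 1.4-fold lower number from compound 1 to compound 2 (0.14 log units; that floor lies within the scatter), concerns a halogen exchange on a different ring and tells little about a methoxy-to-methyl swap on the fused system. For the measured compounds named here, no step that bears directly on the change from compound 3 to compound 4 has been measured. With compound 3 already at a limit, the step of a number no higher from compound 3 to compound 4 (the limit leaves the size open) is expected to stay within the scatter. Compound 4 is accordingly estimated to give 50000 nM, with a range from 25000 nM to 100000 nM, and most likely the assay will again report only a limit.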

Compound 4, half-maximal inhibitory concentration: > 50000 nM
Compound 4 ended at the assay's limit (the forecaster's own chance of this, stated with the estimate: 65%); the middle value lies on the limit itself.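

In this assay, compound 4, with 6-methyl-1,3-benzothiazol-2-yl in place of the 6-methoxy-1,3-benzothiazol-2-yl of compound 3, also ends at a limit, so this change does not bring a number into the reportable range: the limit of > 50000 nM in this assay, at which 3 of the 4 values shown sit. The steps to compound 4 from compound 3 and from compound 1 cannot be read, as both ends of each are limits. Among the compounds shown here, the one readable step is an at least 1.4-fold higher number from compound 2 to compound 4 (0.14 log units; that floor lies within the scatter), with methoxy in place of chloro, and it does not separate the two compounds.

As far as these compounds go, how far compounds 1, 3 and 4 lie beyond the limit remains unknown. Also open, from the compounds shown here alone, is whether an amine or a carboxylic acid on this aromatic carbon would give a readable number.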